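From pyrrolidin-1-yl to cyclopropylamino on a carbonyl carbon

A few compounds are considered here, and "the series" means these few. Any claim that something is new, unique, unknown or untested is made for them only; others in the source may bear on it.

Measured in a toxicity assay on HEK293 cells (Homo sapiens) for inhibition, read by resazurin assay, with a stated time of 24 h (on this read-out lower numbers stand for higher toxicity in this test and higher numbers for lower toxicity in this test), so far
Compound 1 `CN(C)C(=O)c1ncc([N+](=O)[O-])n1C` gives > 100000 nM (a limit)
Compound 2 `Cn1c([N+](=O)[O-])cnc1C(=O)N1CCCC1` gives > 100000 nM (a limit)

Compound 2 stands at > 100000 nM in this assay (a limit of the assay and not a number). Compound 3 `Cn1c([N+](=O)[O-])cnc1C(=O)NC1CC1` carries cyclopropylamino in place of pyrrolidin-1-yl on a carbonyl carbon. Going by the values given here, the one measured step that bears on this is a step that the two limits leave unreadable from compound 1 to compound 2 and it offers no size to carry over. The whole evidence so far is the limit of > 100000 nM in this assay, at which 2 of the 2 values shown sit, and it gives no sign of a step beyond the scatter. The expectation is therefore no step in either direction in this assay and a report as a limit again is likely. The estimated outcome is a step that the limit leaves unreadable from compound 2 to compound 3 in this assay. For compound 3 the expected value is 120000 nM with an estimated range (60000 nM to 250000 nM).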

Compound 3, half-maximal cytotoxic concentration: > 100000 nM
Compound 3 ended at the assay's limit (the forecaster's own chance of this, stated with the estimate: 85%); the middle value does not contradict the limit.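

In this assay compound 3 gives > 100000 nM, a limit of the assay and not a number, and its steps from compound 1 and compound 2 cannot be read. The compounds shown leave open whether any group on that carbonyl carbon would give a measurable value in this assay.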